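A few compounds are considered here, and "the series" means these few. Any claim that something is new, unique, unknown or untested is made for them only; others in the source may bear on it.

Measured in a functional assay (muscle tissue) with Cavia porcellus as the target; a higher number here means that more compound is needed for the effect, a lower number that less compound is needed:
compound 1 `COC(=O)C1=C(C)N=C(C)/C(=C(\O)OC)C1c1cccc(O)c1`: 1000 nM
compound 2 `COC(=O)C1=C(C)N=C(C)/C(=C(\O)OC)C1c1cccc(Br)c1`: 1.29 nM
compound 3 `COC(=O)C1=C(C)N=C(C)/C(=C(\O)OC)C1c1cccc(C)c1`: 110 nM

Compound 3 holds the middle place among these three numbers. It sits well clear of both neighbours, with a 9.1-fold lower number from compound 1 to compound 3 (0.96 log units; beyond the scatter) on one side and an 85-fold higher number from compound 2 to compound 3 (1.93 log units; beyond the scatter) on the other.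

Compound 4 `COC(=O)C1=C(C)N=C(C)/C(=C(\O)OC)C1c1cccc(C(F)(F)F)c1` carries trifluoromethyl in place of methyl on an aromatic carbon. For the measured compounds named here, no measured step makes this exact change, so the evidence is indirect. The three steps that exchange a group at this same carbon are a 780-fold lower number from compound 1 to compound 2 (2.89 log units; beyond the scatter), a 9.1-fold lower number from compound 1 to compound 3 (0.96 log units; beyond the scatter) and an 85-fold higher number from compound 2 to compound 3 (1.93 log units; beyond the scatter): two large and one modest. Exchanges here can therefore move the number a long way in this assay. Going by the values given here, a modest to large step towards a lower number is expected, resting on compound 2 at 1.29 nM, though no measured compound carries fluorine. The estimated change is a 7.9-fold lower number from compound 3 to compound 4 (0.90 log units; beyond the scatter). For compound 4 the estimated value is 14 nM, with an expected range from 2.5 nM to 80 nM.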

Compound 4, half-maximal effective concentration: 74.1 nM
For compound 4 the middle estimate is 5.3-fold (0.72 log units) below the measured one, within the range that was stated.
By their numbers in this assay, from the lowest: compound 2; then compounds 4 and 3 (each within the scatter of the next); then compound 1.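

In this assay, the exchange of methyl for trifluoromethyl on this aromatic carbon gives a 1.5-fold lower number from compound 3 to compound 4 (0.17 log units; within the scatter), so at this position these two groups cannot be told apart, although other exchanges here moved the number a long way. Trifluoromethyl does not match bromo, with a 57-fold higher number from compound 2 to compound 4 (1.76 log units; beyond the scatter), yet it stands clear of hydroxy, with a 13-fold lower number from compound 1 to compound 4 (1.13 log units; beyond the scatter), which leaves compound 2 alone at the low end, compound 1 alone at the high end, and compounds 3 and 4 together in the middle. Nothing available here bears on the reason for this order.

Going by these compounds, it remains open where chloro, iodo or an amine on this carbon would fall relative to bromo and methyl. On these data alone, whether these exchanges would give the same order at another carbon of the aromatic ring also remains open.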